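Chloro for hydrogen on the pendant phenyl: expectation for compound 4

The source may report more compounds than this note shows. Statements on the series, on what has been measured and on what is new or still open speak of the compounds shown alone.

Measured compounds:
compound 1 `CN(C)CCCC1(c2ccc(F)cc2)OCc2cc(-c3ccccc3)ccc21` — 1800 nM
compound 2 `CN(C)CCCC1(c2ccc(F)cc2)OCc2cc(-c3cccc(C#N)c3)ccc21` — 737 nM
compound 3 `CN(C)CCCC1(c2ccc(F)cc2)OCc2cc(CCc3ccccc3)ccc21` — "not determined" (no result reported)

In an assay on Caudate-putamen for displacement of a labelled ligand from sodium-dependent dopamine transporter (Rattus norvegicus), read by scintillation counting (on this read-out higher numbers stand for weaker inhibition and lower numbers for stronger inhibition), compound 1 gives 1800 nM, the highest of the two numbers in hand. Compound 2 gives 737 nM; compound 3 carries no result, its entry reading "not determined" (no result reported). Among the compounds with values here, the only step bearing on the change considered here is a 2.4-fold lower number from compound 1 to compound 2 (0.39 log units; beyond the scatter), a modest lowering beyond the scatter.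

Compound 4 `CN(C)CCCC1(c2ccc(F)cc2)OCc2cc(-c3cccc(Cl)c3)ccc21` differs from compound 1 by chloro in place of hydrogen on an aromatic carbon. A single substituent swap at this position has been measured, so the size of the new step is uncertain. A modest lowering in the same direction is nonetheless expected because a 2.4-fold lower number from compound 1 to compound 2 (0.39 log units; beyond the scatter) points that way for a comparable small substituent at the same place. For compound 4 the expected value is 900 nM, with a range of 400 nM to 2000 nM, which corresponds to an expected step of a 2.0-fold lower number from compound 1 to compound 4 (0.30 log units; within the scatter).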

Compound 4, inhibition constant: 1390 nM
Estimate against measurement, compound 4: 1.5-fold (0.19 log units) below; the measured number falls inside the stated range.
By their numbers in this assay, from the lowest: compounds 2, 4 and 1 (each within the scatter of the next, the first and the last beyond it).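

In this assay, phenyl to 3-chlorophenyl gives a 1.3-fold lower number from compound 1 to compound 4 (0.11 log units; within the scatter), so chloro at this place cannot be told apart from hydrogen, and a lowering beyond the scatter does not follow from any small substituent here. Chloro in place of cyano gives a 1.9-fold higher number from compound 2 to compound 4 (0.28 log units; within the scatter), so compound 4 cannot be told apart from compound 2 either. No available data bear on the reason for these results.

As far as these compounds go, whether an amine, a carboxylic acid or a methoxy group at this place would behave like the nitrile or like chloro remains open. Also open, from the compounds shown here alone, is how chloro would read on another carbon of the pendant phenyl.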